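The source may report more compounds than this note shows. Statements on the series, on what has been measured and on what is new or still open speak of the compounds shown alone.

Measured in a functional assay on C6 cells (Rattus norvegicus) for cytotoxicity, read by MTT assay, with a stated time of 24 h, tested at 6 ug/mL; on this read-out lower numbers stand for a stronger effect and higher numbers for a weaker effect at the one concentration tested:
compound 1 `O=C(CSc1nnnn1-c1ccccc1)N/N=c1/scc(-c2ccc(Br)cc2)n1-c1ccccc1` gives 61.8%
compound 2 `O=C(CSc1ncccn1)N/N=c1/scc(-c2ccc(Br)cc2)n1-c1ccccc1` gives 76.4%

Among the compounds with values here, compound 2 holds the higher of the two numbers in this assay; the one step recorded, a number 14.6 percentage points higher from compound 1 to compound 2 (beyond the scatter), came from the change of the group on the sulfur, the halophenyl part being the same in both.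

Compound 3 `O=C(CSc1ncccn1)N/N=c1/scc(-c2ccc(F)cc2)n1-c1ccccc1` is unmeasured. It differs from compound 2 by fluoro in place of bromo on an aromatic carbon. Within the data shown here, no measured step touches that part of the shared core, so nothing shows how a change of the halogen on that ring moves the read-out; the only recorded step concerns a different place. With no evidence either way, the expectation is a step from compound 2 to compound 3 in this assay of a number 0.4 percentage points lower from compound 2 to compound 3 (within the scatter), that is none beyond the scatter. Compound 3 is therefore estimated at 76%, within 60% to 92%.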

Compound 3, a percentage reported as activity, at one concentration (the size of the read-out at that concentration, not a potency): 84%
Estimate against measurement, compound 3: 8 percentage points below, and the stated range covers the measured number.
By their numbers in this assay, from the lowest: compound 1; then compounds 2 and 3 (each within the scatter of the next).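

In this assay, the exchange of 4-bromophenyl for 4-fluorophenyl gives a number 7.6 percentage points higher from compound 2 to compound 3 (within the scatter), so with pyrimidin-2-yl on the sulfur these two halogens are not told apart at this position. Within the data shown here, this is the only reading so far on the aromatic carbon para to a large group, whereas the earlier step, a number 14.6 percentage points higher from compound 1 to compound 2 (beyond the scatter), concerned only the group on the sulfur and lay beyond the scatter. Nothing measured in this series bears on the reason for this result.

As far as these compounds go, whether the same exchange also reads within the scatter with 1-phenyl-1H-tetrazol-5-yl on the sulfur remains open. Also open, from the compounds shown here alone, is how a group other than a halogen at this place, such as an amine, a methoxy group or a carboxylic acid, would read in this assay.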